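Phenyl to 1-benzofuran-2-yl at the assay limit

The source may report more compounds than this note shows. Statements on the series, on what has been measured and on what is new or still open speak of the compounds shown alone.

Compound 1 `COc1nc(N)nc2c1c(-c1ccco1)cn2[C@@H]1O[C@H](CO)[C@@H](O)[C@H]1O`: > 100000 nM
Compound 2 `COc1nc(N)nc2c1c(-c1ccoc1)cn2[C@@H]1O[C@H](CO)[C@@H](O)[C@H]1O`: > 100000 nM
Compound 3 `COc1nc(N)nc2c1c(-c1ccccc1)cn2[C@@H]1O[C@H](CO)[C@@H](O)[C@H]1O`: > 100000 nM

These results come from an ADME assay on BJ cells (Homo sapiens), read by MTT assay, with a stated time of 72 h (a higher number here means a weaker inhibitor, a lower number a stronger inhibitor), and each is a limit, not a number. Compound 3 therefore has no exact value, and it shares its position with the other two: the limit of > 100000 nM in this assay, at which 3 of the 3 values shown sit. Compound 4 `COc1nc(N)nc2c1c(-c1cc3ccccc3o1)cn2[C@@H]1O[C@H](CO)[C@@H](O)[C@H]1O` has 1-benzofuran-2-yl in place of phenyl on an aromatic carbon. The closest measured changes offer no size to carry over: a step that the two limits leave unreadable from compound 1 to compound 3 and a step that the two limits leave unreadable from compound 2 to compound 3. No clear step is therefore expected in this assay, though any real shift would probably be towards stronger inhibition. The expected step is a number no higher from compound 3 to compound 4 (the limit leaves the size open). For compound 4, the estimated value is 100000 nM, with an expected range from 30000 nM to 100000 nM.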

Compound 4, half-maximal inhibitory concentration: 25600 nM
Compound 4: the middle estimate sits 3.9-fold (0.59 log units) above what was measured, and the stated range ends above it.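

In this assay, this position on the core proves able to shift the result once 1-benzofuran-2-yl is attached, giving an at least 3.9-fold lower number from compound 3 to compound 4 (0.59 log units; beyond the scatter), an at least 3.9-fold lower number from compound 2 to compound 4 (0.59 log units; beyond the scatter) and an at least 3.9-fold lower number from compound 1 to compound 4 (0.59 log units; beyond the scatter). Each step is a minimum, and this rests on compound 4 alone. The steps among phenyl, furan-2-yl and furan-3-yl cannot be read because all three compounds carry the same limit: the limit of > 100000 nM in this assay, at which 3 of the 4 values shown sit.

As far as these compounds go, it remains open whether the ring oxygen of 1-benzofuran-2-yl matters or simply the larger group. A naphthalen-2-yl group, with only carbon in its rings, would help separate the two.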